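This account rests on a few compounds, and the source may have more. Where it says the series, first, only, none or still open, it means among the compounds named here.

Measured compounds, all in a functional assay on CHO cells for agonist activity at prostaglandin E2 receptor EP3 subtype (Homo sapiens), read by fluorescence and calcium flux; a higher number here means that more compound is needed for the effect, a lower number that less compound is needed:
- compound 1, `O=C(O)CCCCCC1=CC[C@@H]2[C@@H](/C=C/[C@@H](O)COc3ccccc3)[C@H](O)C[C@@H]2OC1`, gives 6400 nM
- compound 2, `O=C(O)CC[C@@H]1CC[C@@H]2[C@@H](/C=C/[C@@H](O)COc3ccccc3)[C@H](O)C[C@@H]2OC1`, gives 870 nM
- compound 3, `O=C(O)CC[C@H]1CC[C@@H]2[C@@H](/C=C/[C@@H](O)COc3ccccc3)[C@H](O)C[C@@H]2OC1`, gives 4800 nM

Compound 2 stands at the lowest number of the three in this assay; compound 3 is the nearest to it and compound 1 the furthest, both of their steps from compound 2 lying beyond the scatter. Going by the values given here, the one step within the set that changes a single place is a 5.5-fold higher number from compound 2 to compound 3 (0.74 log units; beyond the scatter), and it rests on (the fact that compounds 2 and 3 differ only in the configuration as drawn), so it says nothing about the length of the acid chain.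

Compound 4, `O=C(O)CCC[C@@H]1CC[C@@H]2[C@@H](/C=C/[C@@H](O)COc3ccccc3)[C@H](O)C[C@@H]2OC1`, is not yet measured. Against compound 2 the change is carboxymethyl in place of carboxy on a saturated chain carbon, two bonds along the chain from a saturated ring carbon. Among the compounds with values here, no measured pair isolates this change: compound 1 carries a longer acid chain than compound 2, but it also differs from compound 2 elsewhere in the core, so the gap between its value and that of compound 2 cannot be read as a chain-length step. The expectation for compound 4 therefore has no measured anchor and is set close to compound 2, with a wide range: a step of a 1.5-fold higher number from compound 2 to compound 4 (0.17 log units; within the scatter) from compound 2 to compound 4 is expected, with neither direction favoured beyond the scatter. Compound 4 is estimated at 1300 nM in this assay, in the range 350 nM to 5000 nM.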

Compound 4, half-maximal effective concentration: 2.3 nM
Compound 4: the middle estimate sits 570-fold (2.75 log units) above what was measured, outside the stated range (below it).
By their numbers in this assay, from the lowest: compound 4; then compound 2; then compounds 3 and 1 (each within the scatter of the next).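

In this assay, the acid chain on this saturated ring carbon proves to be a strong determinant of the read-out: going from 2-carboxyethyl to 3-carboxypropyl, with carboxymethyl in place of carboxy at the chain end, gives a 380-fold lower number from compound 2 to compound 4 (2.58 log units; beyond the scatter). Going by these compounds alone, until now the only single-place step was the change of configuration, a 5.5-fold higher number from compound 2 to compound 3 (0.74 log units; beyond the scatter), and the chain step is clearly the larger of the two, so chain length matters at least as much here as the drawn configuration at that ring carbon. Nothing in the available evidence bears on why this one-carbon extension has so large an effect.

Still open, from the compounds shown here alone, is whether the 3-carboxypropyl chain is an optimum or a point on a continuing trend, which a 4-carboxybutyl chain on the same saturated core would test, and whether the same extension gives a comparable step on the opposite configuration of compound 3. Also open, going by these compounds, is whether the carboxylic acid itself is needed at the chain end, which an amide or a tetrazole there would address.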